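Notes on the step from compound 3 to compound 4

A few compounds are considered here, and "the series" means these few. Any claim that something is new, unique, unknown or untested is made for them only; others in the source may bear on it.

compound 1 `CC(C)N1CCN(CCCN(C[C@H]2Cc3ccccc3CN2)[C@H]2CCCc3cccnc32)CC1` gives 46% 
compound 2 `CCN1CCN(CCCN(C[C@H]2Cc3ccccc3CN2)[C@H]2CCCc3cccnc32)CC1` gives 59% 
compound 3 `c1ccc2c(c1)CN[C@@H](CN(CCCN1CCN(C3CC3)CC1)[C@H]1CCCc3cccnc31)C2` gives 21% 

All three values come from an ADME assay on microsomes from liver (Homo sapiens) for metabolic stability, read by LC-MS, with a stated time of 10 min, tested at 0.5 uM (a higher number here means that more of the compound is left, a lower number that less of the compound is left), as the only read-out. Compound 3 stands lowest at 21% on this scale, and both other compounds lie beyond the scatter above it.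

Compound 4 `c1ccc2c(c1)CN[C@@H](CN(CC[C@H]1CCCNC1)[C@H]1CCCc3cccnc31)C2` carries piperidin-3-yl in place of (4-cyclopropylpiperazin-1-yl)methyl on a saturated chain carbon, two bonds along the chain from an amine nitrogen, counted as piperidin-3-yl in place of (4-cyclopropylpiperazin-1-yl)methyl on a saturated chain carbon, two bonds along the chain from an amine nitrogen in full.

The measured steps touch only the group on an amine nitrogen in a ring. Cyclopropyl in place of ethyl gives a number 38 percentage points lower from compound 2 to compound 3 (beyond the scatter) and cyclopropyl in place of isopropyl gives a number 25 percentage points lower from compound 1 to compound 3 (beyond the scatter) in the same series. The step of a number 13 percentage points higher from compound 1 to compound 2 (beyond the scatter) stays among the open-chain groups. Among the compounds with values here, no measured step replaces the whole group, so these steps guide the estimate only loosely. Compound 4 has no cyclopropyl, and compound 3 at 21% leaves the scale mostly open upward, so a modest rise is expected.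

The expected step is a number 21 percentage points higher from compound 3 to compound 4 (beyond the scatter) in this assay as estimated here.

For compound 4 the estimate is 42% as the expected value, within an expected range from 18% to 68% for now.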

Compound 4, percent of the compound remaining: 93%
Compound 4: middle estimate off by 51 percentage points, on the low side, outside the stated range (above it).
By their numbers in this assay, from the lowest: compound 3; then compound 1; then compound 2; then compound 4.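

In this assay, piperidin-3-yl on the saturated chain carbon, two bonds along the chain from an amine nitrogen, gives a large upward step beyond the scatter against each of the three piperazine-bearing groups: a number 72 percentage points higher from compound 3 to compound 4 (beyond the scatter), a number 34 percentage points higher from compound 2 to compound 4 (beyond the scatter) and a number 47 percentage points higher from compound 1 to compound 4 (beyond the scatter). The earlier compounds shown here varied only the small group on the ring amine nitrogen, whereas this exchange of the whole group places compound 4 highest of the four, so the read-out at this position is not confined to the choice among ethyl, isopropyl and cyclopropyl. Nothing available here accounts for the size of the rise.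

The compounds shown leave open how far the rise belongs to the piperidin-3-yl ring as such, to its defined stereocentre, or to the departure of the piperazine. A 1-methylpiperidin-3-yl or piperidin-4-yl group at the same place, or the opposite stereoisomer of piperidin-3-yl, would begin to separate these readings.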